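Ester and aryl variants held at the cytotoxicity limit

A few compounds are considered here, and "the series" means these few. Any claim that something is new, unique, unknown or untested is made for them only; others in the source may bear on it.

compound 1 `COc1ccc(F)c(-c2ccc(C(=O)N(Cc3cccc(OCCCCCC(=O)O)c3)C(C)C)cc2)c1`: > 26000 nM
compound 2 `CC(C)N(Cc1cccc(OCCCCCC(=O)O)c1)C(=O)c1ccc(-c2cccc(F)c2)cc1`: > 26000 nM
compound 3 `CCOC(=O)CCCCCOc1cccc(CN(C(=O)c2ccc(-c3cc(OC)ccc3F)cc2)C(C)C)c1`: > 26000 nM

Three compounds were tested in an ADME assay on Raji cells (Homo sapiens) for cytotoxicity, read by CellTiter-Glo and resazurin assay, with a stated time of 72 h; a higher number here means that more compound is needed for the effect, a lower number that less compound is needed. In this assay compound 1 reaches only a limit, > 26000 nM. In this assay compound 2 likewise gives only a limit, > 26000 nM. In this assay compound 3 also stops at a limit, > 26000 nM. All three values sit at the limit of > 26000 nM in this assay, at which 3 of the 3 values shown sit, so no number was obtained for any of them.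

Compound 2 differs from compound 1 by 3-fluorophenyl in place of 2-fluoro-5-methoxyphenyl on an aromatic carbon. The resulting step, a step that the two limits leave unreadable from compound 1 to compound 2, cannot be sized because both values are limits. Compound 3 differs from compound 1 by ethyl in place of hydrogen on an oxygen next to a carbonyl group, and that step, a step that the two limits leave unreadable from compound 1 to compound 3, is equally unreadable.

Compound 4 `CCOC(=O)CCCCCOc1cccc(CN(C(=O)c2ccc(-c3cccc(F)c3)cc2)C(C)C)c1` has not been measured. It differs from compound 3 by 3-fluorophenyl in place of 2-fluoro-5-methoxyphenyl on an aromatic carbon. The place of this change is described in the same words as for the change from compound 1 to compound 2, so it is the same change, applied on a core that carries the difference described by ethyl in place of hydrogen on an oxygen next to a carbonyl group. Because the limit of > 26000 nM in this assay, at which 3 of the 3 values shown sit, holds every value shown, compound 4 is expected to remain at the limit as well, and the step that the limit leaves unreadable from compound 3 to compound 4 is expected to be flat. For compound 4 the estimate is 30000 nM, with a range from 20000 nM to 60000 nM.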

Compound 4, half-maximal effective concentration: > 26000 nM
Compound 4: a limit, no number; the forecaster's own chance of this, stated with the estimate: 85%; the middle value lies beyond the limit too.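

In this assay compound 4 gives > 26000 nM, which is a limit and not a number. For the compounds shown here, neither the step from compound 3 to compound 4 nor the one from compound 2 to compound 4 can be read. The compounds shown leave open whether either change, of the aryl group or at the acid oxygen, shifts the true value at all, because all of them stop at one point: the limit of > 26000 nM in this assay, at which 4 of the 4 values shown sit.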